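The compounds below may be only part of what the source reports. "The series", "measured", "known", "first", "only" and "open" are said of these compounds alone.

Working notes on the series. All compounds share one core and differ only in the aromatic group on the carbonyl carbon whose other neighbour is the amide-type nitrogen. Compound 1 `C[C@@H](NC(=O)C1(NC(=O)c2ccc(Br)nc2)CC1)c1ccc(-n2nc(Cl)c3ccccc32)cc1F` gives 2.6 mL/min/kg in an in vivo ADME assay on the whole organism (strain Mongrel) for pharmacokinetics, with Canis familiaris (Canis lupus familiaris) as the target; a higher number here means faster removal of the compound, a lower number slower removal. Compound 2 `C[C@@H](NC(=O)C1(NC(=O)c2cncc(Cl)n2)CC1)c1ccc(-n2nc(Cl)c3ccccc32)cc1F` gives 10.5 mL/min/kg in this assay, and compound 3 `COc1cncc(C(=O)NC2(C(=O)N[C@H](C)c3ccc(-n4nc(Cl)c5ccccc54)cc3F)CC2)c1` gives 5.5 mL/min/kg. Compound 3 thus stands second highest of the three: the step is a 2.1-fold higher number from compound 1 to compound 3 (0.33 log units; beyond the scatter), while a 1.9-fold lower number from compound 2 to compound 3 (0.28 log units; within the scatter) lies within the scatter. The largest swing at this position is a 4.0-fold higher number from compound 1 to compound 2 (0.61 log units; beyond the scatter), still only modest.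

Compound 4 `C[C@@H](NC(=O)C1(NC(=O)c2cncs2)CC1)c1ccc(-n2nc(Cl)c3ccccc32)cc1F` is not yet measured. The change from compound 3 is 1,3-thiazol-5-yl in place of 5-methoxypyridin-3-yl on a carbonyl carbon. Within the data shown here, no measured step involves a 1,3-thiazol-5-yl group, so this swap has no direct precedent; the three steps at this position range from within the scatter to modest, none larger. A step of at most comparable size is therefore expected in this assay, direction open, centred on compound 3. Compound 4 is expected to give 6 mL/min/kg, with a range from 3 mL/min/kg to 13 mL/min/kg. The expected step is a 1.1-fold higher number from compound 3 to compound 4 (0.04 log units; within the scatter).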

Compound 4, clearance: 1.1 mL/min/kg
Estimate against measurement, compound 4: 5.5-fold (0.74 log units) above; the measured number lies below the stated range.
By their numbers in this assay, from the lowest: compound 4; then compound 1; then compounds 3 and 2 (each within the scatter of the next).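

In this assay the 1,3-thiazol-5-yl group gives the lowest number in the series, with a 5.0-fold lower number from compound 3 to compound 4 (0.70 log units; beyond the scatter) and a 2.4-fold lower number from compound 1 to compound 4 (0.37 log units; beyond the scatter). The position therefore spans a wider range than the six-membered aromatic rings alone showed, the widest step now being a 9.5-fold lower number from compound 2 to compound 4 (0.98 log units; beyond the scatter). Nothing measured here accounts for this result.

Among these compounds, compound 4 is the only compound with a five-membered aromatic ring and the only one with sulfur in that ring, so the two features cannot be told apart, and it stays open whether an oxazole or a thiophene on the same carbonyl carbon would give a similarly low number. On these data alone, it also stays open whether a methyl group or an amine on the thiazole ring would keep the number this low.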